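The source may report more compounds than this note shows. Statements on the series, on what has been measured and on what is new or still open speak of the compounds shown alone.

Measured so far:
- compound 1, `COCCOCn1cc[n+](C)c1/C=N/O` — -2.81
- compound 2, `C[n+]1ccn(CCCCC#N)c1/C=N/O` — -2.8

In a physicochemical assay for lipophilicity (a lower number here means a more polar compound, a higher number a more lipophilic compound), compound 2 stands highest of the two numbers, but its nearest neighbour is compound 1 and the step of a number 0.01 log units higher from compound 1 to compound 2 (within the scatter) lies within the scatter, so the two values cannot be ordered. That step exchanged a 2-methoxyethoxy group for a 3-cyanopropyl group on a saturated chain carbon bound to an aromatic nitrogen, and the read-out did not move.

Compound 3, `C[n+]1ccn(CCOCCF)c1/C=N/O`, is the next member and has not been measured in this assay. It differs from compound 2 as follows: 2-fluoroethoxy in place of 2-cyanoethyl on a saturated chain carbon, two bonds along the chain from an aromatic nitrogen. Cut one bond further out, the same difference reads 3-cyanopropyl to (2-fluoroethoxy)methyl, which is close to the reverse of the single measured step. Since that step, from compound 1 to compound 2, stayed within the scatter, a step of no more than the scatter is expected here as well, with the ether-bearing chain of compound 3 leaving the value near that of compound 2.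

Compound 3 is therefore estimated at -2.75, with a range of -3.15 to -2.35, an expected step of a number 0.05 log units higher from compound 2 to compound 3 (within the scatter).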

Compound 3, distribution coefficient: -2.62
The estimate for compound 3 lay 0.13 log units below the measured number, and the stated range covers the measured number.
By their numbers in this assay, from the lowest: compounds 1, 2 and 3 (each within the scatter of the next).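

In this assay, 2-fluoroethoxy in place of 2-cyanoethyl on a saturated chain carbon, two bonds along the chain from an aromatic nitrogen, gives a number 0.18 log units higher from compound 2 to compound 3 (within the scatter) and so shows that the nitrile can be exchanged for an ether chain ending in fluorine without a readable difference, at least for this pair. The remaining pair, with (2-fluoroethoxy)methyl in place of 2-methoxyethoxy on a saturated chain carbon bound to an aromatic nitrogen, gives a number 0.19 log units higher from compound 1 to compound 3 (within the scatter) and so closes the set: each of the three chains lies within the scatter of the other two, and they cannot be ordered in this assay. No measurement shown accounts for this agreement among the three chains.

Whether any group at this position can move the read-out beyond the scatter remains open, as all three chains shown are of similar size and none carries an amine or a carboxylic acid. A longer chain or a chain ending in a hydroxyl group would test the same question.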